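The compounds below may be only part of what the source reports. "The series", "measured", "known", "first", "only" and "open" are said of these compounds alone.

Values in a functional assay on HEK293 cells with D(4) dopamine receptor (Homo sapiens) as the target, read by FLIPR (on this read-out higher numbers stand for an effect only at larger amounts of compound and lower numbers for an effect already at smaller amounts), for the measured members of the series:

compound 1, `O/N=C(\CCN1CCN(c2ccccn2)CC1)c1ccccc1`: 4.4 nM
compound 2, `O/N=C(\CCN1CCN(c2ccccn2)CC1)c1cccc(F)c1`: 17.1 nM
compound 3, `Cc1cccc(/C(CCN2CCN(c3ccccn3)CC2)=N/O)c1`: 2.3 nM

Compound 3 gives the lowest of the three numbers. Its nearest neighbour is compound 1, with a 1.9-fold lower number from compound 1 to compound 3 (0.28 log units; within the scatter) falling within the scatter, so the two are not separable on these data. Compound 2 is furthest away, and a 7.4-fold lower number from compound 2 to compound 3 (0.87 log units; beyond the scatter) is beyond the scatter.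

Compound 4, `Cc1cc(C)cc(/C(CCN2CCN(c3ccccn3)CC2)=N/O)c1`, differs from compound 3 by methyl in place of hydrogen on an aromatic carbon. The step that bears most directly on this is the same change made once already: a 1.9-fold lower number from compound 1 to compound 3 (0.28 log units; within the scatter), which stayed within the scatter. The step of a 7.4-fold lower number from compound 2 to compound 3 (0.87 log units; beyond the scatter) involves a fluoro leaving and is less comparable. Among the compounds with values here, no measured pair shows a second methyl added to a ring already carrying one, so only a weak expectation follows.

On that basis a change no larger than the scatter is expected, a 1.3-fold higher number from compound 3 to compound 4 (0.12 log units; within the scatter). Compound 4 is estimated at 3 nM in this assay, with a range of 1.2 nM to 8 nM.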

Compound 4, half-maximal effective concentration: 45.8 nM
For compound 4 the middle estimate is 15-fold (1.18 log units) below the measured one; measured number outside the range, above it.
By their numbers in this assay, from the lowest: compounds 3 and 1 (each within the scatter of the next); then compound 2; then compound 4.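

In this assay the same replacement of hydrogen by methyl gives a 20-fold higher number from compound 3 to compound 4 (1.30 log units; beyond the scatter) on a ring already carrying a methyl group, against a 1.9-fold lower number from compound 1 to compound 3 (0.28 log units; within the scatter) on the plain phenyl ring, so in this short series the outcome of adding methyl depends on what the ring already carries. The 3,5-dimethylphenyl group also separates compound 4 from the other two, with a 10-fold higher number from compound 1 to compound 4 (1.02 log units; beyond the scatter) on the change from phenyl and a 2.7-fold higher number from compound 2 to compound 4 (0.43 log units; beyond the scatter) on the change from 3-fluorophenyl. Within the data shown here, the two methyl groups together therefore give a result that the single methyl of compound 3 gave no sign of.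

As far as these compounds go, whether a second fluoro, a chloro or a methoxy group at this ring position would give the same higher number stays open. Nothing shown here bears on the reason for this step.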